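The source may report more compounds than this note shows. Statements on the series, on what has been measured and on what is new or still open speak of the compounds shown alone.

Three compounds share one core and differ only in the group on the thiocarbonyl carbon. Compound 1 `CN(C(=S)SCc1ccc(C(=O)Nc2ccccc2N)cc1)c1cccnc1` gives 70.5% in a functional assay on HeLa cells (Homo sapiens) for antiproliferative activity, read by CCK-8 assay, with a stated time of 72 h, tested at 8 uM; on this read-out lower numbers stand for a weaker effect and higher numbers for a stronger effect at the one concentration tested. Compound 2 `CC1CCCCN1C(=S)SCc1ccc(C(=O)Nc2ccccc2N)cc1` gives 76.3% in this assay, and compound 3 `CN1CCN(C(=S)SCc2ccc(C(=O)Nc3ccccc3N)cc2)CC1` gives 75.7% in this assay. Compound 3 stands second highest of the three numbers, with the steps of a number 5.2 percentage points higher from compound 1 to compound 3 (within the scatter) and a number 0.6 percentage points lower from compound 2 to compound 3 (within the scatter) both within the scatter. Compound 4 `CN(Cc1ccncc1)C(=S)SCc1ccc(C(=O)Nc2ccccc2N)cc1` is the next step: methyl((pyridin-4-yl)methyl)amino in place of 4-methylpiperazin-1-yl on a thiocarbonyl carbon. The entering group resembles the methyl(pyridin-3-yl)amino of compound 1, so the step of a number 5.2 percentage points higher from compound 1 to compound 3 (within the scatter) bears most on it; that step and a number 5.8 percentage points higher from compound 1 to compound 2 (within the scatter) both stayed within the scatter. No step beyond the scatter is therefore expected in this assay. Compound 4 is estimated at 72%, between 58% and 84%. The expected step of a number 3.7 percentage points lower from compound 3 to compound 4 (within the scatter) lies within the scatter.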

Compound 4, a percentage reported as inhibition, at one concentration (the size of the read-out at that concentration, not a potency): 72.7%
For compound 4 the middle estimate is 0.7 percentage points below the measured one; low and high end bracket the measured number.
By their numbers in this assay, from the lowest: compounds 1, 4, 3 and 2 (each within the scatter of the next).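

In this assay, a six-membered aromatic ring carried on a methylene in methyl((pyridin-4-yl)methyl)amino gives no step beyond the scatter against the non-aromatic rings (a number 3 percentage points lower from compound 3 to compound 4 (within the scatter); a number 3.6 percentage points lower from compound 2 to compound 4 (within the scatter)). Moving from pyridin-3-yl to (pyridin-4-yl)methyl on an amide-type nitrogen also stays within it (a number 2.2 percentage points higher from compound 1 to compound 4 (within the scatter)), so all four groups on the thiocarbonyl carbon remain inseparable here. No evidence accounts for this result. Going by these compounds, whether a carboxylic acid or a longer alkyl chain at this position would give a step beyond the scatter stays open.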